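The compounds below may be only part of what the source reports. "The series", "measured", "known", "first", "only" and "open" are said of these compounds alone.

Four compounds share one core and differ only in the group carried on the carbonyl carbon of the amide. Compound 1 `O=C(Nc1ccc(Cl)c(-c2nnc3c(Cl)cccn23)c1)c1ccc(C(F)(F)F)cc1F`, compound 2 `CS(=O)(=O)c1ccc(C(=O)Nc2ccc(Cl)c(-c3nnc4c(Cl)cccn34)c2)c(Cl)c1` and compound 3 `O=C(Nc1ccc(Cl)c(-c2nnc3c(Cl)cccn23)c1)c1ccccc1` have been tested in a functional assay on MDA-MB-231 cells (Homo sapiens) for antiproliferative activity, read by MTT assay, with stated times of 72 h and 4 h; a higher number here means a weaker inhibitor, a lower number a stronger inhibitor. For compound 1 the result is a limit of the assay, > 100000 nM, and not a number (the limit of > 100000 nM in this assay, at which 1 of the 3 values shown sits). Compound 2 gives 37200 nM. Compound 3 gives 58200 nM; of the two numbers shown it is the higher, but it and the value of compound 2 lie within the usual scatter of each other, so no real difference between them is claimed. Compound 4 `Cc1nc(C(=O)Nc2ccc(Cl)c(-c3nnc4c(Cl)cccn34)c2)cs1` has not yet been measured in this assay. It differs from compound 3 by 2-methyl-1,3-thiazol-4-yl in place of phenyl on a carbonyl carbon. Going by the values given here, no measured pair shows a change of this kind, so nothing in the data tells how large its effect will be. The expected step, a 1.2-fold lower number from compound 3 to compound 4 (0.07 log units; within the scatter), is small and stays within the scatter. Compound 4 is therefore estimated to give about 50000 nM in this assay, with a plausible range from 15000 nM to 150000 nM.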

Compound 4, half-maximal inhibitory concentration: > 100000 nM
Compound 4 gave a limit, no number (the forecaster's own chance of this, stated with the estimate: 25%); middle value at least 2.0-fold (0.30 log units) away from the limit.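

In this assay, placing 2-methyl-1,3-thiazol-4-yl instead of phenyl on the carbonyl carbon gives an at least 1.7-fold higher number from compound 3 to compound 4 (0.23 log units; that floor lies within the scatter). This is the first step at this position that can be read from a matched pair, and it shows no gain from the five-membered ring with its hydrogen-bond acceptors, although the floor of the step lies within the scatter, so a real loss is not shown either. The true size of the step stays unknown, because compound 4 gives a limit and not a number: the limit of > 100000 nM in this assay, at which 2 of the 4 values shown sit.

The compounds shown leave open whether a group of another kind on this carbonyl carbon, such as an amine or a longer alkyl chain, would give a clearly lower number. Also open, from the compounds shown here alone, is how the same five-membered ring would behave without its methyl group.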